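A few compounds are considered here, and "the series" means these few. Any claim that something is new, unique, unknown or untested is made for them only; others in the source may bear on it.

Measured in an assay on COS-1 cells for inhibition of alkaline phosphatase, tissue-nonspecific isozyme (Homo sapiens), read by colorimetric assay; a lower number here means a stronger inhibitor, a higher number a weaker inhibitor:

Compound 1, `COc1cc(C)c(Cl)cc1S(=O)(=O)Nc1cccnc1`: 510 nM
Compound 2, `COc1cc(S(=O)(=O)Nc2cccnc2)c(OC)cc1Cl`: 1130 nM

Going by the values given here, of the two numbers measured so far, compound 2 holds the higher one, and its distance from the value of compound 1 lies beyond the usual scatter, so compound 2 is the weaker inhibitor of this pair. Among the compounds with values here, the two compounds differ in more than one place, so no single step between them can be read off.

Compound 3, `COc1cc(S(=O)(=O)Nc2cccnc2)c(OC)cc1C`, has not yet been measured. It differs from compound 2 in one place: methyl in place of chloro on an aromatic carbon. The exchange keeps the number of heavy atoms, the donor and acceptor count and the charge unchanged; it is a methyl in place of a chloro on an aromatic carbon. Within the data shown here, nothing among the measured compounds isolates that exchange at that place, so there is no direct precedent for its size. The expected step of a 1.2-fold higher number from compound 2 to compound 3 (0.09 log units; within the scatter) is therefore small, in either direction, and not beyond the scatter. Compound 3 is estimated to give 1400 nM in this assay, with a likely range from 600 nM to 3500 nM.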

Compound 3, half-maximal inhibitory concentration: 1490 nM
Estimate against measurement, compound 3: 1.1-fold (0.03 log units) below; the range from low to high includes it.
By their numbers in this assay, from the lowest: compound 1; then compounds 2 and 3 (each within the scatter of the next).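

In this assay, going by these compounds alone, the exchange of chloro for methyl on the aromatic carbon para to a large group gives a 1.3-fold higher number from compound 2 to compound 3 (0.12 log units; within the scatter), so this place tolerates either group without a separation in the read-out, and this is the first single-place step available. A second exchange, methoxy in place of chloro at a different aromatic carbon, gives a 2.9-fold higher number from compound 1 to compound 3 (0.47 log units; beyond the scatter), a modest loss that lies beyond the scatter and shows that the number can respond to a change at that other place, unlike the change at the first. No measurement shown here offers an explanation for either step.

As far as these compounds go, each exchange is seen only once and on one background, so it remains open whether the tolerance of chloro and methyl at the first place would hold for a group such as an amine, a carboxylic acid or a longer chain. From the compounds shown here alone, it is equally open whether a fluoro or a bromo at the second place would keep the number of compound 1 or move it towards that of compound 3.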